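Compound 2 and the loss of its ring methyl

The compounds below may be only part of what the source reports. "The series", "measured", "known", "first", "only" and "open" are said of these compounds alone.

Measured so far in a functional assay on HT-29 cells (Homo sapiens) for cytotoxicity, read by MTT assay, with a stated time of 72 h (a higher number here means a weaker inhibitor, a lower number a stronger inhibitor), for three compounds:
- compound 1 `O=C(CN1CCN(c2nnc(Cc3ccncc3)c3ccccc23)CC1)Nc1ccc(Br)cc1` gives 1990 nM
- compound 2 `Cc1ccc(F)cc1NC(=O)CN1CCN(c2nnc(Cc3ccccc3)c3ccccc23)CC1` gives 171000 nM
- compound 3 `Cc1ccc(F)cc1NC(=O)CN1CCN(c2nnc(Cc3ccncc3)c3ccccc23)CC1` gives 470 nM

Compound 2 has the highest number of the three. Compound 4 `O=C(CN1CCN(c2nnc(Cc3ccccc3)c3ccccc23)CC1)Nc1cccc(F)c1` departs from it by hydrogen in place of methyl on an aromatic carbon and so carries 3-fluorophenyl in place of 5-fluoro-2-methylphenyl. The closest evidence, a swap of the group on the amide-type nitrogen, is a 4.2-fold lower number from compound 1 to compound 3 (0.63 log units; beyond the scatter) and is modest. The other step, a 360-fold lower number from compound 2 to compound 3 (2.56 log units; beyond the scatter) and large, lies elsewhere and bears only indirectly. For the measured compounds named here, no measured step isolates the methyl. A modest step towards a lower number is therefore expected in this assay with little confidence in its direction. The expected change is a 2.9-fold lower number from compound 2 to compound 4 (0.45 log units; beyond the scatter) by this estimate. Compound 4 is estimated at 60000 nM with an expected range of 12000 nM to 250000 nM for now.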

Compound 4, half-maximal inhibitory concentration: 95000 nM
Compound 4: middle estimate off by 1.6-fold (0.20 log units), on the low side; the range from low to high includes it.
By their numbers in this assay, from the lowest: compound 3; then compound 1; then compounds 4 and 2 (each within the scatter of the next).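

In this assay, for the compounds shown here, the methyl is now isolated for the first time: hydrogen in its place gives a 1.8-fold lower number from compound 2 to compound 4 (0.26 log units; within the scatter) with the phenyl group on the saturated chain carbon. On this background, the methyl para to the fluoro group therefore makes no readable difference, and the high numbers of compound 2 and compound 4 stand together. No supporting data bear on why this is so.

On these data alone, whether the same swap stays within the scatter with the pyridin-4-yl group of compound 3 remains open. Also open, as far as these compounds go, is how a methoxy group or an amine would read on this aromatic carbon.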